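The source may hold more compounds than are shown below. What is called first, only, known or untested is meant among the compounds shown, and "the series" means these compounds.

Compound 1, `O=C1c2nccnc2C(=O)N1Cc1ccccc1`: in an ADME assay on Vero cells (Chlorocebus sabaeus) for cytotoxicity (a lower number here means a stronger inhibitor, a higher number a weaker inhibitor), compound 1 reaches only the limit of > 100000 nM.
Compound 2, `C[C@@H](c1ccccc1)N1C(=O)c2nccnc2C1=O`: in this assay compound 2 gives 85000 nM.

For the measured compounds named here, compound 2 stands alone as the one compound with an actual number in this assay; the other value shown is a limit, as the limit of > 100000 nM in this assay, at which 1 of the 2 values shown sits, records. Going by the values given here, the single measured step, an at least 1.1-fold lower number from compound 1 to compound 2 (0.07 log units; that floor lies within the scatter), introduced a methyl in place of hydrogen on the saturated chain carbon bound to the amide-type nitrogen in the ring and to the aromatic carbon, and its floor lies within the scatter.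

Compound 3, `C[C@H](c1ccccc1)N1C(=O)c2nccnc2C1=O`, differs from compound 2 as follows: the two compounds have the same atoms and bonds and differ only in configuration as drawn: 1 of 1 stereo elements differ; a stereocentre at a saturated chain carbon is drawn S in compound 2 and R in compound 3. Among the compounds with values here, no measured step concerns a change of configuration alone; the step from compound 1 to compound 2 changed the atoms present, not their arrangement in space. With nothing in the data pointing either way, compound 3 is expected to show no step beyond the scatter, that is no change at the digits printed from compound 2 to compound 3 (within the scatter). Compound 3 is therefore estimated at 85000 nM in this assay, within a range of 40000 nM to 180000 nM.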

Compound 3, half-maximal inhibitory concentration: 79000 nM
The estimate for compound 3 lay 1.1-fold (0.03 log units) above the measured number; low and high end bracket the measured number.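

In this assay, the change of configuration at the saturated chain carbon, drawn S in compound 2 and R in compound 3, gives a 1.1-fold lower number from compound 2 to compound 3 (0.03 log units; within the scatter), so this stereocentre makes no readable difference here, and the reading is a clean one: the fact that compounds 2 and 3 differ only in the configuration as drawn. Methyl in place of hydrogen on that carbon, now with the R configuration, gives an at least 1.2-fold lower number from compound 1 to compound 3 (0.10 log units; that floor lies within the scatter), so with either configuration the step from compound 1 has a floor that does not leave the scatter. As far as these compounds go, compound 1 remains a limit, and the full size of the methyl step therefore stays unknown: the limit of > 100000 nM in this assay, at which 1 of the 3 values shown sits.

The compounds shown leave open whether an ethyl group or a longer chain in place of the methyl, or an amine or a carboxylic acid on that chain, would move the number in this assay beyond the scatter. From the compounds shown here alone, whether the configuration at this carbon would still make no readable difference with such a group in place also stays open.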